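Two Sulfonamide Pairs and a Methyl Step

The compounds below may be only part of what the source reports. "The series", "measured", "known", "first", "only" and "open" are said of these compounds alone.

Compound 1 `O=S(=O)(Nc1ccccc1NS(=O)(=O)c1ccc(F)cc1)c1ccc(F)cc1` — 28300 nM
Compound 2 `Cc1ccc(NS(=O)(=O)c2ccc(F)cc2)c(NS(=O)(=O)c2ccc(F)cc2)c1` — 16200 nM
Compound 3 `O=S(=O)(Nc1ccccc1NS(=O)(=O)c1cccc(Cl)c1)c1cccc(Cl)c1` — 5700 nM

Of the compounds shown here, three have been measured in an assay for binding affinity to protein lin-28 homolog A (Mus musculus), with a stated time of 1 h; a higher number here means a weaker inhibitor, a lower number a stronger inhibitor. Compound 1 gives 28300 nM and compound 2 gives 16200 nM in this assay. The two differ in one place, (methyl in place of hydrogen on an aromatic carbon), and the step is a 1.7-fold lower number from compound 1 to compound 2 (0.24 log units; within the scatter). Compound 3 gives 5700 nM in this assay, the lowest of the three numbers; its gap to compound 2 and to compound 1 is beyond the scatter. The difference between the core of compound 3 and the core of compound 1 is not broken down here.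

Compound 4 `Cc1ccc(NS(=O)(=O)c2cccc(Cl)c2)c(NS(=O)(=O)c2cccc(Cl)c2)c1` has not yet been measured. It differs from compound 3 by methyl in place of hydrogen on an aromatic carbon, the same change that separates compound 2 from compound 1, made on the core of compound 3. Since that earlier step was a 1.7-fold lower number from compound 1 to compound 2 (0.24 log units; within the scatter), the step from compound 3 to compound 4 is expected to be of similar small size, a 1.5-fold lower number from compound 3 to compound 4 (0.18 log units; within the scatter). Compound 4 is therefore estimated at 3800 nM in this assay, with a range from 1500 nM to 9500 nM.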

Compound 4, half-maximal inhibitory concentration: 4300 nM
The estimate for compound 4 lay 1.1-fold (0.05 log units) below the measured number, within the range that was stated.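

In this assay, methyl in place of hydrogen on an aromatic carbon gives a 1.3-fold lower number from compound 3 to compound 4 (0.12 log units; within the scatter). Set beside the earlier step, the change carries from one core to the other without a difference that can be told apart: the same change on two cores in this assay, a 1.7-fold lower number (0.24 log units; within the scatter) from compound 1 to compound 2 and a 1.3-fold lower number (0.12 log units; within the scatter) from compound 3 to compound 4, 1.3-fold (0.12 log units) apart, within the scatter of two such steps. This shows that on these two cores the methyl leaves the number within the scatter, but it does not show that the methyl strengthens binding, since neither step is beyond the scatter, and two cores cannot establish how the change would behave on any other core in the series.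

The compounds shown leave open whether a larger or different group at this place, such as an ethyl, a methoxy group, an amine or a carboxylic acid, would move the number beyond the scatter. They also leave open which part of the difference between the core of compound 3 and the core of compound 1 accounts for the gap between their values.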